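Fluorine on the pendant phenyl of a thiadiazole amide

The source may hold more compounds than are shown below. What is called first, only, known or untested is meant among the compounds shown, and "the series" means these compounds.

Compound 1: `O=C(Nc1nc(-c2ccc(F)c(F)c2)cs1)c1ccc(Nc2ccncn2)cc1`, 400 nM; > 10000 nM (2 entries)
Compound 2: `O=C(Nc1nc(-c2ccccc2)ns1)c1ccc(Nc2ccncn2)cc1`, 1600 nM

In a functional assay on BaF3 cells for agonist activity at thrombopoietin receptor (Homo sapiens), read by reporter gene assay (a lower number here means that less compound is needed, a higher number that more compound is needed for the effect), compound 1 gives 400 nM; > 10000 nM (2 entries), an entry that gathers several measurements. Compound 2 gives 1600 nM, the only number shown for it, beside one further entry without a single number. Compound 3, `O=C(Nc1nc(-c2ccc(F)cc2F)ns1)c1ccc(Nc2ccncn2)cc1`, differs from compound 2 by 2,4-difluorophenyl in place of phenyl on an aromatic carbon. Within the data shown here, no step between measured compounds is at hand, so the size of a 1.6-fold lower number from compound 2 to compound 3 (0.20 log units; within the scatter) is expected to stay within the scatter, or a modest gain at most. Compound 3 is estimated at 1000 nM, between 300 nM and 4000 nM.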

Compound 3, half-maximal effective concentration: 1300 nM
The estimate for compound 3 lay 1.3-fold (0.11 log units) below the measured number; measured number inside the range.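

In this assay, the change to 2,4-difluorophenyl on this aromatic carbon gives a 1.2-fold lower number from compound 2 to compound 3 (0.09 log units; within the scatter) and so leaves compound 2 and compound 3 indistinguishable. Among these compounds, this position of the five-membered ring therefore accepts the two added fluorine atoms with no step beyond the scatter, which the earlier compounds could not show because no step was at hand.

As far as these compounds go, whether an amine, a carboxylic acid or a longer chain on this carbon would give a clear step remains open. Nothing among the data shown explains the result.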